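The source may hold more compounds than are shown below. What is called first, only, known or untested is meant among the compounds shown, and "the series" means these compounds.

Going by the values given here, compound 1 `ClCc1ccc(Cn2cnc3c(Cl)ncnc32)cc1` is one of two compounds measured in this set. In a functional assay on HOP-62 cells (Homo sapiens) for cytotoxicity, read by sulforhodamine B assay, with a stated time of 48 h (on this read-out higher numbers stand for lower toxicity in this test and lower numbers for higher toxicity in this test), compound 1 gives 32400 nM, the higher of the two numbers recorded. The other measured compound, compound 2 `ClCc1cccc(Cn2cnc3c(Cl)nc(Cl)nc32)c1`, gives 8310 nM in this assay, and the gap between the two values lies beyond the usual scatter of such measurements. Among the compounds with values here, because the two compounds differ in more than one place, no single step between them is counted; their values show only that compound 2 sits lower.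

Compound 3 `Nc1nc(Cl)c2ncn(Cc3ccc(CCl)cc3)c2n1` has not yet been tested. It differs from compound 1 in one place: amino in place of hydrogen on an aromatic carbon. Within the data shown here, there is no step between measured compounds differing in a single place to show what such a change does, so the expectation rests on the standing of compound 1 alone. A modest shift toward a lower number is expected, one that may still fall within the scatter. The step of a 1.6-fold lower number from compound 1 to compound 3 (0.21 log units; within the scatter) is therefore expected to be small. Compound 3 is estimated at 20000 nM in this assay, with a range from 7000 nM to 60000 nM.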

Compound 3, concentration lethal to 50% of the cells: 91200 nM
The estimate for compound 3 lay 4.6-fold (0.66 log units) below the measured number; measured number outside the range, above it.
By their numbers in this assay, from the lowest: compound 2; then compound 1; then compound 3.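

Amino in place of hydrogen on an aromatic carbon, between two ring nitrogen atoms, provides the only single-place comparison in this set: in this assay, the change gives a 2.8-fold higher number from compound 1 to compound 3 (0.45 log units; beyond the scatter). This shows that, on the core of compound 1, adding the amino group at this position is accompanied by a modest move toward the higher numbers that stand for lower toxicity in this test, a step that lies beyond the usual scatter. The data shown offer no measured basis for explaining this step.

On these data alone, whether a methylamino group, a hydroxyl group or a methoxy group on the same carbon would move the number in the same direction remains open. So does whether the amino group would produce a similar step on the core of compound 2, which carries its chloromethyl group at a different place, since this single pair cannot show how far the result extends beyond compound 1 and compound 3.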